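Compound 3 to compound 4: replacing 3,5-dichlorophenyl

This account rests on a few compounds, and the source may have more. Where it says the series, first, only, none or still open, it means among the compounds named here.

In an ADME assay on HEK-293T cells (Homo sapiens) for cytotoxicity, read by CCK-8 assay, with a stated time of 48 h (a lower number here means a stronger inhibitor, a higher number a weaker inhibitor), compound 3 `Cc1ccc(-c2ccsc2S(=O)(=O)NCCNC(=O)Nc2cc(Cl)cc(Cl)c2)c(Oc2ccc(O)c(O)c2)c1` gives 6700 nM and compound 2 `Cc1ccc(-c2ccsc2S(=O)(=O)NCCNC(=S)Nc2ccc([N+](=O)[O-])cc2)c(Oc2ccc(O)c(O)c2)c1` gives 8200 nM, within the scatter of each other (a 1.2-fold lower number from compound 2 to compound 3 (0.09 log units; within the scatter)). Compound 1 `COc1ccc(NC(=O)NCCNS(=O)(=O)c2sccc2-c2ccc(C)cc2Oc2ccc(O)c(O)c2)cc1` gives only a limit (> 20000 nM). Compound 4 `Cc1ccc(-c2ccsc2S(=O)(=O)NCCNC(=O)Nc2cccc([N+](=O)[O-])c2)c(Oc2ccc(O)c(O)c2)c1` carries 3-nitrophenyl in place of 3,5-dichlorophenyl on an amide-type nitrogen. The same place changes in the step of an at least 2.9-fold lower number from compound 1 to compound 3 (0.47 log units; beyond the scatter), which brings in 3,5-dichlorophenyl in place of 4-methoxyphenyl and is at least modest. Among the measured compounds shown here, the closest precedent is compound 2, which also holds a nitrophenyl group and gives 8200 nM in this comparison. The expected step (a 1.5-fold higher number from compound 3 to compound 4 (0.17 log units; within the scatter)) is a slight move to a higher number, not beyond the scatter. For compound 4 the estimated value is 10000 nM (expected range 5000 nM to 20000 nM).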

Compound 4, half-maximal inhibitory concentration: 6800 nM
Beside the measured number, compound 4's estimate is 1.5-fold (0.17 log units) above it, and the stated range covers the measured number.
By their numbers in this assay, from the lowest: compounds 3, 4 and 2 (each within the scatter of the next). At a limit, above all of these: compound 1.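

In this assay, 3-nitrophenyl and 3,5-dichlorophenyl on the amide-type nitrogen are not told apart (a 1.0-fold higher number from compound 3 to compound 4 (0.01 log units; within the scatter)), and compound 4 also stays within the scatter of compound 2 (a 1.2-fold lower number from compound 2 to compound 4 (0.08 log units; within the scatter)). Among the compounds shown here, only 4-methoxyphenyl stands apart at this position so far, with an at least 2.9-fold lower number from compound 1 to compound 4 (0.46 log units; beyond the scatter). Compound 1 is a limit, not a number: the limit of > 20000 nM in this assay, at which 1 of the 4 values shown sits.

On these data alone, whether that gap follows the methoxy group itself or its place on the ring stays open, with 3-methoxyphenyl as the missing comparison. Also open, as far as these compounds go, is how the number responds to an amine or a carboxylic acid on this phenyl ring, or to a longer chain in the linker.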